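A few compounds are considered here, and "the series" means these few. Any claim that something is new, unique, unknown or untested is made for them only; others in the source may bear on it.

Compound 1 `CC1=CC[C@H](C(C)(C)NC(=S)N/N=C/c2ccc(O)cc2)CC1`: in a functional assay on K562 cells (Homo sapiens) for inhibition, read by sulforhodamine B assay, with a stated time of 48 h (on this read-out lower numbers stand for stronger inhibition of growth and higher numbers for weaker inhibition of growth), compound 1 gives > 100000 nM, which is a limit of the assay rather than a number.
Compound 2 `CC1=CC[C@H](C(C)(C)NC(=S)N/N=C/c2ccccc2O)CC1`: in this assay compound 2 gives 800 nM.
Compound 3 `CC1=CC[C@H](C(C)(C)NC(=S)N/N=C/c2ccc(F)cc2)CC1`: in this assay compound 3 gives > 100000 nM, again a limit of the assay.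

Compound 3 therefore stands at the limit of > 100000 nM in this assay, at which 2 of the 3 values shown sit, with no measured number of its own. Compound 4 `CC1=CC[C@H](C(C)(C)NC(=S)N/N=C/c2ccc(Cl)cc2)CC1` differs from compound 3 in one place: chloro in place of fluoro on an aromatic carbon. The measured steps that bear on this position are an at least 120-fold lower number from compound 1 to compound 2 (2.09 log units; beyond the scatter) and an at least 120-fold higher number from compound 2 to compound 3 (2.09 log units; beyond the scatter), while a step that the two limits leave unreadable from compound 1 to compound 3. Only compound 2 gives a readable number; compound 1 and compound 3, each carrying a different group on the same aromatic carbon as compound 4, both sit at the limit. Exchanging fluoro for chloro there is therefore expected to leave compound 4 at or near that limit, with no step beyond the scatter readable. The step from compound 3 to compound 4 is estimated as a number no higher from compound 3 to compound 4 (the limit leaves the size open). Compound 4 is expected to give 100000 nM, in the range 30000 nM to 300000 nM.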

Compound 4, concentration for 50% growth inhibition: 300 nM
For compound 4 the middle estimate is 330-fold (2.52 log units) above the measured one; measured number below the stated range.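

In this assay, a single atom exchanged on this aromatic carbon separates a compound at the limit from a readable one: chloro in place of fluoro gives an at least 330-fold lower number from compound 3 to compound 4 (2.52 log units; beyond the scatter), and chloro in place of hydroxy gives an at least 330-fold lower number from compound 1 to compound 4 (2.52 log units; beyond the scatter). Within the data shown here, compound 2 was the only readable compound before, but a hydroxy group on the ring is clearly not required, since the 4-chlorophenyl group gives a 2.7-fold lower number from compound 2 to compound 4 (0.43 log units; beyond the scatter), a modest step. Compound 1 and compound 3 remain at a limit of the assay rather than a number: the limit of > 100000 nM in this assay, at which 2 of the 4 values shown sit.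

The compounds shown leave open whether this gain is particular to chloro or would also appear with bromo, methyl, trifluoromethyl or an amine on the same aromatic carbon. They also cannot say whether chloro would have the same effect on a different core.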